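A few compounds are considered here, and "the series" means these few. Any claim that something is new, unique, unknown or untested is made for them only; others in the source may bear on it.

Compound 3 `Nc1ccccc1NC(=O)c1ccc(CSC(=S)N2CCN(c3ccc(F)cc3)CC2)cc1` stands highest among the three numbers in a functional assay on HeLa cells (Homo sapiens) for antiproliferative activity, read by CCK-8 assay, with a stated time of 72 h, tested at 2 uM (on this read-out higher numbers stand for a stronger effect at the one concentration tested and lower numbers for a weaker effect), giving 60.8%; compound 1 `Nc1ccccc1NC(=O)c1ccc(CSC(=S)N2CCN(Cc3ccccn3)CC2)cc1` gives 14.2% and compound 2 `Nc1ccccc1NC(=O)c1ccc(CSC(=S)N2CCN(C(c3ccccc3)c3ccccc3)CC2)cc1` gives 8%. Compound 4 `CN1CCN(C(=S)SCc2ccc(C(=O)Nc3ccccc3N)cc2)CC1` differs from compound 3 by methyl in place of 4-fluorophenyl on an amine nitrogen in a ring. Among the compounds with values here, the one relevant step is a number 46.6 percentage points higher from compound 1 to compound 3 (beyond the scatter), which shows that replacing a non-aryl group on the ring nitrogen with an aryl moves the read-out strongly; compound 2, with another non-aryl group, sits near compound 1. Within the data shown here, no measured pair tests methyl itself. Compound 4 is therefore expected to fall back toward the non-aryl compounds, by an estimated a number 35.8 percentage points lower from compound 3 to compound 4 (beyond the scatter). The expected value for compound 4 in this assay is 25%, with a range from 5% to 55%.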

Compound 4, a percentage reported as inhibition, at one concentration (the size of the read-out at that concentration, not a potency): 52.6%
The estimate for compound 4 lay 27.6 percentage points below the measured number, within the range that was stated.
By their numbers in this assay, from the lowest: compounds 2 and 1 (each within the scatter of the next); then compounds 4 and 3 (each within the scatter of the next).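

In this assay, the ring amine nitrogen tolerates a change from 4-fluorophenyl to methyl, with a number 8.2 percentage points lower from compound 3 to compound 4 (within the scatter), so an aryl group at this position is not required for a high read-out. The a number 38.4 percentage points higher from compound 1 to compound 4 (beyond the scatter) shows that a non-aryl group here does not by itself give a low number, and compound 1 and compound 2 are the ones that stay low. No evidence on the origin of these differences is available.

Open, on these data alone, is how a benzyl group or an ethyl group on this nitrogen would read. Also open, as far as these compounds go, is whether a longer chain ending in an amine or a carboxylic acid would keep the read-out of compound 4.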